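Amide Versus Amine on the Shared Core

The compounds below may be only part of what the source reports. "The series", "measured", "known", "first", "only" and "open" are said of these compounds alone.

Compound 1 `COc1c(NS(=O)(=O)c2ccc(F)cc2)cc(-c2ccc3nc(NC(C)=O)sc3c2)cc1C(N)=O`: 4750 nM in a functional assay on U-87MG ATCC cells (Homo sapiens) for antiproliferative activity, read by MTT assay, with a stated time of 72 h; a higher number here means a weaker inhibitor, a lower number a stronger inhibitor.
Compound 2 `COc1c(NS(=O)(=O)c2ccc(F)cc2)cc(-c2ccc3nc(NC4CC4)sc3c2)cc1C(N)=O`: "not determined" (no result reported) in this assay.

Compound 2 stands nowhere on the numbers: in this assay compound 2 is "not determined" (no result reported), so it offers no footing of its own. Compound 3 `COc1c(NS(=O)(=O)c2ccc(F)cc2)cc(-c2ccc3nc(NC(=O)C4CC4)sc3c2)cc1C(N)=O` differs from compound 2 by cyclopropylcarbonyl in place of cyclopropyl on a nitrogen on an aromatic ring. Within the data shown here, with no measured step for this change, neither its size nor its direction can be read from the data. Among the measured compounds shown here, the only anchor is compound 1, which in this assay gives 4750 nM. Because compound 1 gives 4750 nM, compound 3 is estimated near 4000 nM, expected to fall between 1000 nM and 16000 nM.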

Compound 3, half-maximal inhibitory concentration: 2870 nM
Compound 3: middle estimate off by 1.4-fold (0.14 log units), on the high side; the measured number falls inside the stated range.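

Putting cyclopropyl in place of methyl on the carbonyl carbon gives a 1.7-fold lower number from compound 1 to compound 3 (0.22 log units; within the scatter) in this assay, so these two amides read as alike at this position. Compound 2 has no reported result, so the step from its cyclopropylamino group to the (cyclopropylcarbonyl)amino group of compound 3 cannot be read. Nothing measured here offers an explanation for this result.

Still open, as far as these compounds go, is whether a longer chain or a phenyl ring on the carbonyl carbon would shift the number beyond the usual scatter. From the compounds shown here alone, a plain amine on the shared core also remains untested against these amides.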